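Urea tail swap on a shared core against the Ret V804L variant

A few compounds are considered here, and "the series" means these few. Any claim that something is new, unique, unknown or untested is made for them only; others in the source may bear on it.

Measured compounds:
compound 1 `O=C(Nc1ccc(Nc2ncnc3c2OCCN3)cc1)Nc1ccc(Cl)c(C(F)(F)F)c1`, 285 nM
compound 2 `Cc1ccc(F)c(NC(=O)Nc2ccc(Nc3ncnc4c3OCCN4)cc2)c1`, 7000 nM
compound 3 `O=C(Nc1ccc(Nc2ncnc3c2OCCN3)cc1)Nc1cccc(-c2ccccc2)c1`, > 10000 nM

In an assay on isolated protein for inhibition of proto-oncogene tyrosine-protein kinase receptor Ret variant V804L (Homo sapiens), read by 33P incorporation, with stated times of 15 min and 40 min (on this read-out lower numbers stand for stronger inhibition and higher numbers for weaker inhibition), compound 2 gives 7000 nM, the higher of the two numbers in hand, and compound 1 gives 285 nM, a gap beyond the scatter. Compound 3 reaches only (the limit of > 10000 nM in this assay, at which 1 of the 3 values shown sits), a limit rather than a number. The untested compound 4 `CC(C)(C)c1csc(NC(=O)Nc2ccc(Nc3ncnc4c3OCCN4)cc2)n1` differs from compound 2 by 4-(tert-butyl)-1,3-thiazol-2-yl in place of 2-fluoro-5-methylphenyl on an amide-type nitrogen. Going by the values given here, with no measured pair of this kind, the expected step from compound 2 to compound 4 in this assay is a moderate decrease in number, a 5.8-fold lower number from compound 2 to compound 4 (0.77 log units; beyond the scatter), resting on compound 1 at 285 nM showing that the shared core can reach lower values. Compound 4 is therefore estimated at 1200 nM, within 200 nM to 7000 nM.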

Compound 4, half-maximal inhibitory concentration: > 10000 nM
Compound 4: no number, only a limit (the forecaster's own chance of this, stated with the estimate: 15%); middle value at least 8.3-fold (0.92 log units) from the limit.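

Putting 4-(tert-butyl)-1,3-thiazol-2-yl in place of 2-fluoro-5-methylphenyl on this amide-type nitrogen brought no gain in this assay; the step reads an at least 1.4-fold higher number from compound 2 to compound 4 (0.15 log units; that floor lies within the scatter). Compound 4 has a limit and not a number, so this five-membered tail shares its result with the biphenyl-type tail of compound 3: the limit of > 10000 nM in this assay, at which 2 of the 4 values shown sit.

As far as these compounds go, how far compound 4 truly lies from compound 2 stays open. So does whether a methyl group in place of the tert-butyl on the same 1,3-thiazol-2-yl ring would return a measurable number.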